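A few compounds are considered here, and "the series" means these few. Any claim that something is new, unique, unknown or untested is made for them only; others in the source may bear on it.

Compound 1 `CC1CCC(=NNc2ccc(Br)cc2Cl)c2ncc(C(=O)O)c(=O)n21`: > 100 umol/kg
Compound 2 `CCc1nc2n(c(=O)c1C(N)=O)C(C)CCC2=NNc1ccccc1`: > 100 umol/kg
Compound 3 `CC1CC/C(=N\N)c2ncc(C(=O)O)c(=O)n21`: > 100 umol/kg

All three were tested in a functional assay on the whole organism with Rattus norvegicus as the target; on this read-out higher numbers stand for an effect only at larger amounts of compound and lower numbers for an effect already at smaller amounts. For compound 1 the value > 100 umol/kg is a limit of the assay, not a number. For compound 2 the value > 100 umol/kg is likewise a limit. For compound 3 the value > 100 umol/kg is a limit as well. Compound 1 therefore stands at the limit of > 100 umol/kg in this assay, at which 3 of the 3 values shown sit. Compound 4 `CNN=C1CCC(C)n2c1ncc(C(=O)O)c2=O` differs from compound 1 in one place: methyl in place of 4-bromo-2-chlorophenyl on an amine nitrogen. Going by the values given here, no step between two measured compounds is known, so the measured compounds alone cannot show how large this change should be or in which direction it acts. The expected step that the limit leaves unreadable from compound 1 to compound 4 is no more than the usual scatter. Compound 4 is estimated to give about 200 umol/kg in this assay, with a range from 100 umol/kg to 1000 umol/kg.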

Compound 4, dose for 50% inhibition: > 100 umol/kg
Compound 4: only a limit was reported; the forecaster's own chance of this, stated with the estimate: 80%; the middle value lies beyond the limit too.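

In this assay compound 4 gives > 100 umol/kg as a limit and not a number. Going by these compounds alone, compound 1 also has only a limit, so no step between compound 1 and compound 4 can be read. On these data alone, whether methyl in place of 4-bromo-2-chlorophenyl changes the dose needed for an effect stays open.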